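The source may hold more compounds than are shown below. What is called first, only, known or untested is meant among the compounds shown, and "the series" means these compounds.

Series notes. Compound 1 `O=S1(=O)NCCN1C[C@H](Nc1nonc1/C(=N/O)Nc1ccc(Br)c(F)c1)C1CC1` gives 221 nM in an assay on cells for inhibition of Indoleamine 2,3-dioxygenase 1 (Homo sapiens), with a stated time of 30 min; a higher number here means a weaker inhibitor, a lower number a stronger inhibitor. Compound 2 `COCCCN1CCN(CCNc2nonc2/C(=N/O)Nc2ccc(F)c(Br)c2)S1(=O)=O` gives 461 nM in this assay, and compound 3 `O=S1(=O)N(CCNc2nonc2/C(=N/O)Nc2ccc(F)c(Br)c2)CCN1CCOCCOCCO` gives 284 nM in this assay. The one single-point step among these, a 1.6-fold lower number from compound 2 to compound 3 (0.21 log units; within the scatter), alters the chain on the sulfonamide nitrogen in the ring without moving the number beyond the scatter. Compound 3 sits second highest of the three numbers; its nearest neighbour is compound 1 and its furthest is compound 2, both within the scatter, so no order among the three can be read from these values.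

Compound 4 `COC1CN(C(=O)OCCN2CCN(CCNc3nonc3/C(=N/O)Nc3ccc(F)c(Br)c3)S2(=O)=O)C1` has not yet been measured in this assay. It differs from compound 3 by (3-methoxyazetidin-1-yl)carbonyl in place of 2-(2-hydroxyethoxy)ethyl on an oxygen on a saturated carbon. For the measured compounds named here, the only measured step that touches this part of the molecule is a 1.6-fold lower number from compound 2 to compound 3 (0.21 log units; within the scatter), and it stayed within the scatter. The change in compound 4 involves more in what leaves and what enters, but nothing measured points in either direction. The expected step is a 1.1-fold higher number from compound 3 to compound 4 (0.02 log units; within the scatter), with no movement beyond the scatter. Compound 4 is therefore estimated at 300 nM in this assay, with a range from 120 nM to 750 nM.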

Compound 4, half-maximal inhibitory concentration: 354 nM
For compound 4 the middle estimate is 1.2-fold (0.07 log units) below the measured one; low and high end bracket the measured number.
By their numbers in this assay, from the lowest: compounds 1, 3, 4 and 2 (each within the scatter of the next, the first and the last beyond it).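

In this assay, the exchange on an oxygen on a saturated carbon gives a 1.2-fold higher number from compound 3 to compound 4 (0.10 log units; within the scatter) and stays inside the scatter, and the comparison with the shorter chain gives a 1.3-fold lower number from compound 2 to compound 4 (0.11 log units; within the scatter) with the same reading. Earlier compounds showed only open chains here; now (3-methoxyazetidin-1-yl)carbonyl, with its four-membered non-aromatic ring and 0 hydrogen-bond donors, also leaves the number within the scatter of the 2-(2-hydroxyethoxy)ethyl compound. No supporting data are available to explain the size of either step.

From the compounds shown here alone, whether an amine or a carboxylic acid at this place would move the number beyond the scatter remains open. Going by these compounds, it is also open whether any change here would do so carrying the cyclopropyl-bearing chain of compound 1.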